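Swapping the amide side chain: ring for branched chain

The source may report more compounds than this note shows. Statements on the series, on what has been measured and on what is new or still open speak of the compounds shown alone.

Compound 2 `CC(C)CC(=O)N1CCN(c2nc(=O)c3cc(C(F)(F)F)cc([N+](=O)[O-])c3s2)CC1` stands highest of the two numbers in a physicochemical assay for solubility, read by HPLC (on this read-out lower numbers stand for lower solubility and higher numbers for higher solubility), giving 66.3 ug/mL; compound 1 `O=C(C1CCCC1)N1CCN(c2nc(=O)c3cc(C(F)(F)F)cc([N+](=O)[O-])c3s2)CC1` gives 5.34 ug/mL. Among the measured compounds shown here, the only measured step, a 12-fold higher number from compound 1 to compound 2 (1.09 log units; beyond the scatter), is large. Compound 3 `O=C(c1ccc(F)cc1)N1CCN(c2nc(=O)c3cc(C(F)(F)F)cc([N+](=O)[O-])c3s2)CC1` carries the change (4-fluorophenyl in place of isobutyl on a carbonyl carbon). Since the entering group again brings a ring, as cyclopentyl does in compound 1, a large drop is expected, about a 17-fold lower number from compound 2 to compound 3 (1.22 log units; beyond the scatter). Compound 3 is therefore estimated at 4 ug/mL, within 1 ug/mL to 20 ug/mL.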

Compound 3, solubility: 1.69 ug/mL
Compound 3: middle estimate off by 2.4-fold (0.37 log units), on the high side; the range from low to high includes it.
By their numbers in this assay, from the lowest: compound 3; then compound 1; then compound 2.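

With the 4-fluorophenyl on this carbonyl carbon, the isobutyl compound's lead widens: a 39-fold lower number from compound 2 to compound 3 (1.59 log units; beyond the scatter) in this assay is a large drop. The aromatic ring also reads under the cyclopentyl ring, since a 3.2-fold lower number from compound 1 to compound 3 (0.50 log units; beyond the scatter) is a modest step that still lies beyond the scatter. Among these three compounds, then, both ring-bearing groups sit well under the open chain, and the two rings differ from each other. Nothing measured here explains these differences.

Still open, as far as these compounds go, is whether this ordering holds for other groups on the same carbon, such as a longer chain, an amine or a carboxylic acid.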